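The source may report more compounds than this note shows. Statements on the series, on what has been measured and on what is new or still open speak of the compounds shown alone.

Three analogues of one shared core have been measured in a functional assay on A549 cells (Homo sapiens) for antiproliferative activity, read by MTT assay, with a stated time of 48 h; on this read-out higher numbers stand for weaker inhibition and lower numbers for stronger inhibition; they differ only in the aryl group on an aromatic nitrogen of a five-membered aromatic ring with 3 nitrogen. Compound 1 `CCc1ccccc1-n1nncc1CN1C(=O)C2(C(C#N)=C(N)Oc3c(N)cc4nc5ccccc5nc4c32)c2ccccc21` carries 2-ethylphenyl there, and in this assay compound 1 gives 24600 nM. Compound 2 `N#CC1=C(N)Oc2c(N)cc3nc4ccccc4nc3c2C12C(=O)N(Cc1cnnn1-c1ccc(Cl)cc1)c1ccccc12` carries 4-chlorophenyl; for compound 2 this assay reports only a limit, > 50000 nM. Compound 3 `CCOc1ccc(-n2nncc2CN2C(=O)C3(C(C#N)=C(N)Oc4c(N)cc5nc6ccccc6nc5c43)c3ccccc32)cc1` carries 4-ethoxyphenyl; for compound 3 this assay likewise reports only a limit, > 50000 nM. Thus compound 3 stands at the limit of > 50000 nM in this assay, at which 2 of the 3 values shown sit, with no number of its own. The measured steps read an at least 2.0-fold higher number from compound 1 to compound 2 (0.30 log units; that floor lies within the scatter) and an at least 2.0-fold higher number from compound 1 to compound 3 (0.30 log units; that floor lies within the scatter), while the step that the two limits leave unreadable from compound 2 to compound 3 stays unreadable. Compound 4 `CCc1cccc(C)c1-n1nncc1CN1C(=O)C2(C(C#N)=C(N)Oc3c(N)cc4nc5ccccc5nc4c32)c2ccccc21` differs from compound 3 in that (2-ethyl-6-methylphenyl in place of 4-ethoxyphenyl on an aromatic nitrogen). The change brings the aryl group back toward the 2-ethylphenyl of compound 1, so the step from compound 1 to compound 3 is the one that bears on it; its floor lies within the scatter, so a return toward the number of compound 1 is expected but its size is open. Compound 4 is expected to give 25000 nM, within 8000 nM to 60000 nM, an estimated step of an at least 2.0-fold lower number from compound 3 to compound 4 (0.30 log units; that floor lies within the scatter).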

Compound 4, half-maximal inhibitory concentration: > 50000 nM
Compound 4 was reported as a limit; the forecaster's own chance of this, stated with the estimate: 35%; middle value at least 2.0-fold (0.30 log units) away from the limit.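

In this assay, compound 4 is reported only as a limit, so 2-ethyl-6-methylphenyl joins the two para-free... 

Correction, final notes:

In this assay, compound 4 is reported only as a limit, and compound 1 remains the only analogue here with a number of its own: the limit of > 50000 nM in this assay, at which 3 of the 4 values shown sit.

The step that adds methyl on an aromatic carbon of the 2-ethylphenyl group reads an at least 2.0-fold higher number from compound 1 to compound 4 (0.30 log units; that floor lies within the scatter), so keeping the 2-ethyl group does not by itself keep a measured number in this small set. The steps from compound 2 and from compound 3 to compound 4 cannot be read, as limits stand at both ends.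

With a single number in the set, no order can be given among compound 2, compound 3 and compound 4. On these data alone, whether a plain phenyl, a 2-methylphenyl or a 2-aminophenyl group on the same ring nitrogen would give a number near or below that of compound 1 stays open.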